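The source may hold more compounds than are shown below. What is called first, only, known or untested is meant among the compounds shown, and "the series" means these compounds.

Compound 1 `OC1CNCCC1N1CCN(c2ccccc2)CC1` gives 100 nM in an assay on PC-12 cells for displacement of a labelled ligand from vesicular acetylcholine transporter (Homo sapiens); on this read-out higher numbers stand for weaker inhibition and lower numbers for stronger inhibition.
Compound 2 `OC1CCN(Cc2cccc(Br)c2)CC1N1CCN(c2ccccc2)CC1` gives 46 nM in this assay.
Compound 3 `OC1CCN(Cc2ccc(Br)cc2)CC1N1CCN(c2ccccc2)CC1` gives > 100 nM in this assay; this is a limit of the measurement, not a number.

On these data alone, compound 3 therefore stands at the limit of > 100 nM in this assay, at which 1 of the 3 values shown sits, and where it truly lies beyond that boundary is unknown. The change to compound 4 `C/C=C/CN1CCC(O)C(N2CCN(c3ccccc3)CC2)C1` is prop-1-en-1-yl in place of 4-bromophenyl on a saturated chain carbon bound to an amine nitrogen in a ring. Going by the values given here, the one measured step, an at least 2.1-fold higher number from compound 2 to compound 3 (0.33 log units; beyond the scatter), only moved the bromine around the ring; no measured step covers removing the aromatic ring in favour of a short chain. Compound 1, with nothing on that ring nitrogen, gives 100 nM, while compound 2 gives 46 nM. A small chain is expected to leave compound 4 near compound 1, so compound 4 is estimated at 100 nM (range 30 nM to 400 nM), an expected step of a number no higher from compound 3 to compound 4 (the limit leaves the size open).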

Compound 4, half-maximal inhibitory concentration: > 100 nM
Compound 4: no number, only a limit (the forecaster's own chance of this, stated with the estimate: 40%); the middle value lies on the limit itself.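

Prop-1-en-1-yl in place of 3-bromophenyl on a saturated chain carbon bound to an amine nitrogen in a ring gives an at least 2.1-fold higher number from compound 2 to compound 4 (0.33 log units; beyond the scatter), so a small chain does not keep the value reached with 3-bromophenyl. Among the compounds with an aromatic or chain group at this place, only the 3-bromophenyl one now gives a number in this assay, while the other two stop at a limit of the measurement: the limit of > 100 nM in this assay, at which 2 of the 4 values shown sit. Compound 3 and compound 4 are both limits, so the step between them cannot be read.

On these data alone, how far either lies beyond the limit stays open. So does what an unsubstituted phenyl, a longer chain or an amine would give at this place.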